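A fluorine moved, with only limits to go on

This account rests on a few compounds, and the source may have more. Where it says the series, first, only, none or still open, it means among the compounds named here.

Compound 1 `C=C[C@@](C)(/C=C/c1ccc(Nc2ccccc2)cc1)CCC=C(C)C`, compound 2 `C=C[C@@](C)(/C=C/c1ccc(Nc2ccc(OC)cc2)cc1)CCC=C(C)C` and compound 3 `C=C[C@@](C)(/C=C/c1ccc(-c2ccc(F)cc2)cc1)CCC=C(C)C` have all been tested in an ADME assay on BJ cells (Homo sapiens) for cytotoxicity, with a stated time of 72 h (on this read-out higher numbers stand for an effect only at larger amounts of compound and lower numbers for an effect already at smaller amounts), and none of them has yet given a true number. Compound 1 reads > 36600 nM here, which is a limit of the assay. Compound 2 reads > 36600 nM here, again a limit. Compound 3 reads > 36600 nM here, also a limit. Compound 3 therefore stands level with the other two as far as can be told, with nothing to rank it.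

Compound 4 `C=C[C@@](C)(/C=C/c1ccc(-c2cccc(F)c2)cc1)CCC=C(C)C` differs from compound 3 in one place, described by 3-fluorophenyl in place of 4-fluorophenyl on an aromatic carbon, so that 3-fluorophenyl replaces 4-fluorophenyl on an aromatic carbon. Within the data shown here, the steps that bear on this change are a step that the two limits leave unreadable from compound 1 to compound 3 and a step that the two limits leave unreadable from compound 2 to compound 3, along with a step that the two limits leave unreadable from compound 1 to compound 2, so none offers a size to carry over. All that the measured compounds share is the limit of > 36600 nM in this assay, at which 3 of the 3 values shown sit, and no change so far has moved a compound off it. No step beyond the scatter is therefore expected, and no direction can be given. The expected step is a step that the limit leaves unreadable from compound 3 to compound 4 in this estimate. For compound 4 the estimate is 40000 nM, with an expected range from 20000 nM to 80000 nM, and the result will most likely be reported as a limit again.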

Compound 4, half-maximal effective concentration: > 36600 nM
Compound 4 ended at the assay's limit (the forecaster's own chance of this, stated with the estimate: 85%); the middle value lies beyond the limit too.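

No new step can be read: compound 3 and compound 4 both end at a limit of the assay, so swapping 4-fluorophenyl for 3-fluorophenyl has no measurable size, and the steps from compound 1 and compound 2 to compound 4 are just as unreadable. The compounds shown leave open how they truly rank in this assay, and whether any change to the shared core would give a true number, as all that can be seen so far is this: the limit of > 36600 nM in this assay, at which 4 of the 4 values shown sit.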